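The source may report more compounds than this note shows. Statements on the series, on what has been measured and on what is new or still open speak of the compounds shown alone.

In a functional assay on HEL cells (Homo sapiens) (a lower number here means that less compound is tolerated, a higher number that more compound is tolerated), compound 3 (`COC(=O)NC1=CS(=O)(=O)O[C@@]12[C@@H](CO[Si](C)(C)C(C)(C)C)O[C@@H](n1cc(C)c(=O)n(C)c1=O)[C@@H]2O[Si](C)(C)C(C)(C)C`) gives > 200000 nM, which is a limit of the assay and not a number. Its place on the numbers shown is the limit of > 200000 nM in this assay, at which 1 of the 3 values shown sits. Compound 1 (`CCOC(=O)CNC(=O)NC1=CS(=O)(=O)O[C@@]12[C@@H](CO[Si](C)(C)C(C)(C)C)O[C@@H](n1cc(C)c(=O)n(C)c1=O)[C@@H]2O[Si](C)(C)C(C)(C)C`) gives 13000 nM, and compound 2 (`Cc1cn([C@@H]2O[C@H](CO[Si](C)(C)C(C)(C)C)[C@@]3(OS(=O)(=O)C=C3NC(N)=O)[C@H]2O[Si](C)(C)C(C)(C)C)c(=O)n(C)c1=O`) gives 11000 nM. These two are matched, with a 1.2-fold lower number from compound 1 to compound 2 (0.07 log units; within the scatter). Both measured steps that end at the limit are large: an at least 15-fold higher number from compound 1 to compound 3 (1.18 log units; beyond the scatter) and an at least 18-fold higher number from compound 2 to compound 3 (1.25 log units; beyond the scatter).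

Compound 4 (`Cc1cn([C@@H]2O[C@H](CO[Si](C)(C)C(C)(C)C)[C@@]3(OS(=O)(=O)C=C3NCC(=O)OCc3ccccc3)[C@H]2O[Si](C)(C)C(C)(C)C)c(=O)n(C)c1=O`) has (benzyloxycarbonyl)methyl in place of methoxycarbonyl on an amine nitrogen. Going by the values given here, no measured step makes this exact change, so the evidence is indirect. Among the compounds with values here, still, the methoxycarbonyl group occurs only in compound 3, the one measured compound at the limit. Compound 1, which carries an ester-bearing methyl group of a related kind, reaches 13000 nM. A large step toward a lower number is therefore expected, roughly the reverse of an at least 15-fold higher number from compound 1 to compound 3 (1.18 log units; beyond the scatter). The expected step is an at least 6.6-fold lower number from compound 3 to compound 4 (0.82 log units; beyond the scatter). For compound 4 the estimate is 30000 nM, with an expected range from 8000 nM to 200000 nM.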

Compound 4, half-maximal cytotoxic concentration: > 200000 nM
Compound 4: no number, only a limit; the forecaster's own chance of this, stated with the estimate: 25%; at least 6.6-fold (0.82 log units) between middle value and limit.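

In this assay compound 4 gives a limit of the assay and not a number, and compound 3 gives one too: the limit of > 200000 nM in this assay, at which 2 of the 4 values shown sit. Compound 4 stands well apart from the two compounds that have numbers, with an at least 18-fold higher number from compound 2 to compound 4 (1.25 log units; beyond the scatter) and an at least 15-fold higher number from compound 1 to compound 4 (1.18 log units; beyond the scatter). Among the compounds shown, the limit was tied until now to methoxycarbonyl alone, but it is also reached with (benzyloxycarbonyl)methyl on the amine nitrogen, while only the carbamoyl and ((ethoxycarbonyl)methyl)carbamoyl compounds give numbers.

From the compounds shown here alone, the step between compound 3 and compound 4 cannot be read, so how far either lies past the limit remains unknown. Going by these compounds, it is also open whether a carboxylic acid in place of the benzyl ester, or a plain methyl group on that nitrogen, would stay at the limit.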